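Propylpyrazole for aminomethyl-oxazole on the shared core

The source may report more compounds than this note shows. Statements on the series, on what has been measured and on what is new or still open speak of the compounds shown alone.

Measured compounds:
compound 1 `C=CNCc1cc(-c2c(C(=O)NCC)noc2-c2cc(C(C)C)c(O)cc2O)on1`, 43 nM
compound 2 `CCNC(=O)c1noc(-c2cc(C(C)C)c(O)cc2O)c1-c1cc(CNC(=O)CC)no1`, "not determined" (no result reported)

For the measured compounds named here, compound 1 `C=CNCc1cc(-c2c(C(=O)NCC)noc2-c2cc(C(C)C)c(O)cc2O)on1` is the only compound with a number in a functional assay on A2780 cells (Homo sapiens) for inhibition; on this read-out higher numbers stand for weaker inhibition and lower numbers for stronger inhibition; compound 1 gives 43 nM, and compound 2 `CCNC(=O)c1noc(-c2cc(C(C)C)c(O)cc2O)c1-c1cc(CNC(=O)CC)no1` is recorded as "not determined" (no result reported) in this assay. Going by the values given here, no step between two measured compounds is available.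

Compound 3 `CCCn1ccc(-c2c(C(=O)NCC)noc2-c2cc(C(C)C)c(O)cc2O)n1` differs from compound 1 by 1-propyl-1H-pyrazol-3-yl in place of 3-((vinylamino)methyl)-1,2-oxazol-5-yl on an aromatic carbon. Among the compounds with values here, with no measured step to lean on, the expected step of a 1.5-fold higher number from compound 1 to compound 3 (0.18 log units; within the scatter) is small, at most a modest move toward weaker inhibition, likely within the scatter. Compound 3 is therefore estimated at 65 nM, expected between 20 nM and 220 nM.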

Compound 3, half-maximal inhibitory concentration: 27 nM
Beside the measured number, compound 3's estimate is 2.4-fold (0.38 log units) above it; the measured number falls inside the stated range.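

Replacing 3-((vinylamino)methyl)-1,2-oxazol-5-yl with 1-propyl-1H-pyrazol-3-yl on this aromatic carbon gives a 1.6-fold lower number from compound 1 to compound 3 (0.20 log units; within the scatter) in this assay. The position therefore keeps a reading in the same range with a substituent that has no hydrogen-bond donor and no side-chain double bond. No supporting evidence bears on this result.

Still open, on these data alone, is how a butyl chain, or a chain ending in a primary amine or a carboxylic acid, would read in place of the propyl group of 1-propyl-1H-pyrazol-3-yl.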